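Allyl in place of isobutyl on the shared core

The compounds below may be only part of what the source reports. "The series", "measured", "known", "first", "only" and "open" are said of these compounds alone.

Compound 1 `CC(C)[C@H](C(=O)Nc1ncc(C(F)(F)F)s1)c1ccc(Cl)cc1` gives 1500 nM in a functional assay on CHO cells for agonist activity at Free fatty acid receptor 2 (Homo sapiens), read by cAMP accumulation; on this read-out higher numbers stand for weaker inhibition and lower numbers for stronger inhibition.
Compound 2 `CCC[C@H](C(=O)Nc1nccs1)c1ccc(Cl)cc1` gives 5500 nM in this assay.
Compound 3 `CC(C)C[C@H](C(=O)Nc1nccs1)c1ccc(Cl)cc1` gives 600 nM in this assay.

Compound 3 stands lowest of the three numbers; the nearest is compound 1, beyond the scatter, and the furthest is compound 2, also beyond the scatter. Compound 4 `C=CC[C@H](C(=O)Nc1nccs1)c1ccc(Cl)cc1` differs from compound 3 in one place: vinyl in place of isopropyl on a saturated chain carbon, two bonds along the chain from an aromatic carbon and a carbonyl carbon. Among the measured compounds shown here, one measured step bears on this change, a 9.2-fold lower number from compound 2 to compound 3 (0.96 log units; beyond the scatter), in which a methyl added to the chain gave a markedly lower number. Compound 4 undoes that branching and carries a shorter chain with a double bond instead, so its chain is nearer to that of compound 2 than to that of compound 3. For the measured compounds named here, the double bond has no precedent among the measured compounds, which leaves the size uncertain. Compound 4 is therefore expected to give a higher number than compound 3, with a step of a 5.0-fold higher number from compound 3 to compound 4 (0.70 log units; beyond the scatter). Compound 4 is estimated at 3000 nM, within a range of 1000 nM to 9000 nM.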

Compound 4, half-maximal inhibitory concentration: 1100 nM
Compound 4: the middle estimate sits 2.7-fold (0.44 log units) above what was measured; measured number inside the range.
By their numbers in this assay, from the lowest: compounds 3, 4 and 1 (each within the scatter of the next, the first and the last beyond it); then compound 2.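

At this position on the shared core, allyl and isobutyl cannot be told apart in this assay, with a 1.8-fold higher number from compound 3 to compound 4 (0.26 log units; within the scatter). Set against the unbranched chain of compound 2, the allyl chain gives a 5.0-fold lower number from compound 2 to compound 4 (0.70 log units; beyond the scatter), so the branching methyl of a 9.2-fold lower number from compound 2 to compound 3 (0.96 log units; beyond the scatter) is not the only change here that lowers the number beyond the scatter: vinyl in place of ethyl does so too. No evidence is at hand that accounts for this result.

On these data alone, whether a cyclopropylmethyl group, a propargyl group or a longer chain at this position would read with compound 3 and compound 4 or with compound 2 stays open. As far as these compounds go, it is also open whether allyl and isobutyl would stay this close on the core of compound 1, which carries a trifluoromethyl group.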